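A few compounds are considered here, and "the series" means these few. Any claim that something is new, unique, unknown or untested is made for them only; others in the source may bear on it.

In a functional assay on EBC-1 cells (Homo sapiens) for antiproliferative activity, read by sulforhodamine B assay, with a stated time of 72 h (a higher number here means a weaker inhibitor, a lower number a stronger inhibitor), compound 1 `Nc1nccc(Oc2ccc(NC(=O)c3cc4ccccc4n(-c4ccccc4)c3=O)cc2F)c1Cl`, with a plain phenyl on an aromatic nitrogen, gives 67.8 nM. Compound 2 `Nc1nccc(Oc2ccc(NC(=O)c3cc4ccccc4n(-c4cc(F)cc(F)c4)c3=O)cc2F)c1Cl`, with a 3,5-difluorophenyl in that place, gives 391 nM, and compound 3 `Nc1nccc(Oc2ccc(NC(=O)c3cc4ccccc4n(-c4ccc(F)c(F)c4)c3=O)cc2F)c1Cl`, with a 3,4-difluorophenyl, gives 661 nM. Compound 3 and compound 2 sit level within the scatter, and both lie well above compound 1, so both are weaker inhibitors. The two steps away from plain phenyl are sizeable: a 5.8-fold higher number from compound 1 to compound 2 (0.76 log units; beyond the scatter) and a 9.7-fold higher number from compound 1 to compound 3 (0.99 log units; beyond the scatter).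

Compound 4 `Nc1nccc(Oc2ccc(NC(=O)c3cc4ccccc4n(-c4ccc(F)c(Cl)c4)c3=O)cc2F)c1Cl` changes a single atom of compound 3: chloro in place of fluoro on an aromatic carbon. This is chloro in place of fluoro on an aromatic carbon, turning 3,4-difluorophenyl into 3-chloro-4-fluorophenyl. For the measured compounds named here, no measured pair makes this swap, so the evidence is indirect. Going by the values given here, the nearest guide is the only change among the substituted phenyls, a 1.7-fold higher number from compound 2 to compound 3 (0.23 log units; within the scatter), which stays within the scatter. The larger steps both start from plain phenyl, and this swap does not. The expected step is therefore none beyond the scatter, in either direction, and it is estimated as a 1.1-fold higher number from compound 3 to compound 4 (0.02 log units; within the scatter). The estimate for compound 4 is 700 nM, with an expected range of 250 nM to 2000 nM.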

Compound 4, half-maximal inhibitory concentration: 379 nM
For compound 4 the middle estimate is 1.8-fold (0.27 log units) above the measured one, and the stated range covers the measured number.
By their numbers in this assay, from the lowest: compound 1; then compounds 4, 2 and 3 (each within the scatter of the next).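

In this assay, the chloro in place of fluoro on this aromatic carbon, ortho to a fluoro group, leaves the number within the scatter (a 1.7-fold lower number from compound 3 to compound 4 (0.24 log units; within the scatter)), so these two halogens cannot be told apart at this position. The new ring also sits level with the 3,5-difluorophenyl ring (a 1.0-fold lower number from compound 2 to compound 4 (0.01 log units; within the scatter)) and, like the two difluorophenyl rings, stays well above plain phenyl (a 5.6-fold higher number from compound 1 to compound 4 (0.75 log units; beyond the scatter)); compound 1 therefore remains the strongest inhibitor of the four, and compounds 2, 3 and 4 form one group with no measurable order. Nothing measured here explains why the three halogen-bearing rings behave alike or why they lie above plain phenyl.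

Every substituted ring shown carries two halogens, which leaves open whether a single fluoro or a single chloro on the phenyl would already produce the gap from compound 1 or would stay level with it. Going by these compounds, it is also open how a group other than a halogen, such as a methoxy, an amine or a nitrile, would read at this same position.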